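The source may hold more compounds than are shown below. What is called first, only, known or untested is meant among the compounds shown, and "the series" means these compounds.

Working notes on the series. Compound 1 `COc1cccc(Oc2ccc3c(NCCCNCc4cc(F)ccc4OC)ccnc3c2)c1` and compound 2 `CN(C)c1cccc(Oc2ccc3c(NCCCNCc4ccco4)ccnc3c2)c1` share the same core and the same diamine chain. In a physicochemical assay for solubility, with a stated time of 18 h, at pH 7.4 (a lower number here means a less soluble compound, a higher number a more soluble compound), compound 1 gives 14500 nM, and in this assay compound 2 gives 14500 nM, so compound 2 stands level with compound 1 at the digits shown, within the scatter. Compound 3 `COc1ccc(F)cc1CNCCCNc1ccnc2cc(Oc3cccc(N(C)C)c3)ccc12` has not yet been run. It differs from compound 2 by 5-fluoro-2-methoxyphenyl in place of furan-2-yl on a saturated chain carbon bound to an amine nitrogen. Going by the values given here, no step between measured compounds isolates this change, so only a small step, downward or none beyond the scatter, is expected in this assay from compound 2 to compound 3, namely a 1.3-fold lower number from compound 2 to compound 3 (0.12 log units; within the scatter). Compound 3 is estimated at 11000 nM, with a range from 4000 nM to 30000 nM.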

Compound 3, solubility: 14500 nM
Beside the measured number, compound 3's estimate is 1.3-fold (0.12 log units) below it, within the range that was stated.
By their numbers in this assay, from the lowest: compounds 1, 2 and 3 (each within the scatter of the next).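

In this assay, 5-fluoro-2-methoxyphenyl in place of furan-2-yl on a saturated chain carbon bound to an amine nitrogen gives no change at the digits printed from compound 2 to compound 3 (within the scatter), so this larger aromatic ring leaves the read-out unmoved at this position. Dimethylamino in place of methoxy on an aromatic carbon, now also seen alone, gives no change at the digits printed from compound 1 to compound 3 (within the scatter). No data bear on what lies behind these readings. As far as these compounds go, whether a carboxylic acid on that chain carbon, or a longer chain, would move the number in this assay stays open.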